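Bromo added to the fluoro compound

The source may hold more compounds than are shown below. What is called first, only, known or untested is meant among the compounds shown, and "the series" means these compounds.

Compound 1 `c1ccc(-c2nn(-c3ccccc3)cc2-c2nc3ccccc3[nH]2)cc1`: 2710 nM
Compound 2 `O=C(OCc1ccccc1)c1ccc2[nH]c(-c3cn(-c4ccccc4)nc3-c3ccccc3)nc2c1`: 19300 nM
Compound 3 `Fc1ccc(-c2nn(-c3ccccc3)cc2-c2nc3ccccc3[nH]2)cc1`: 1510 nM

In a functional assay on A549 cells (Homo sapiens) for antiproliferative activity, read by MTT assay, with a stated time of 48 h (a higher number here means a weaker inhibitor, a lower number a stronger inhibitor), compound 3 stands level with compound 1 (a 1.8-fold lower number from compound 1 to compound 3 (0.25 log units; within the scatter)) and both lie well under compound 2. Compound 4 `Fc1ccc(-c2nn(-c3ccccc3)cc2-c2nc3cc(Br)ccc3[nH]2)cc1` differs from compound 3 by bromo in place of hydrogen on an aromatic carbon. The fluoro step above was made on another ring, so it says little here. The benzyloxycarbonyl step (a 7.1-fold higher number from compound 1 to compound 2 (0.85 log units; beyond the scatter)) fell on the same fused ring, but with a far bigger group than bromo. A small rise is therefore expected, probably none beyond the scatter. The estimated change is a 1.2-fold higher number from compound 3 to compound 4 (0.08 log units; within the scatter) in this reading. Compound 4 is expected at 1800 nM (range 600 nM to 5500 nM).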

Compound 4, half-maximal inhibitory concentration: 5830 nM
Estimate against measurement, compound 4: 3.2-fold (0.51 log units) below; measured number outside the range, above it.
By their numbers in this assay, from the lowest: compounds 3 and 1 (each within the scatter of the next); then compound 4; then compound 2.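

Until now, only the benzyloxycarbonyl group of compound 2 had tested this six-membered aromatic ring, but a substituent of a single heavy atom also moves the number, with a 3.9-fold higher number from compound 3 to compound 4 (0.59 log units; beyond the scatter) in this assay. Hydrogen on this carbon is therefore not freely replaceable, even by bromo. Nothing available explains the rise.

The compounds shown leave open whether an amine or a carboxylic acid on this carbon would also raise the number. As far as these compounds go, whether bromo would have the same effect on compound 1, which lacks the fluoro, also remains open.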